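A Chlorine Step Carried from One Core to Another

The compounds below may be only part of what the source reports. "The series", "measured", "known", "first", "only" and "open" are said of these compounds alone.

Compound 1 `COc1ccc(C2N=C(SCc3ccccc3)NC(C)=C2C(=O)Nc2ccc(F)cc2)cc1OC` gives 8.8% in a functional assay on the whole organism (artery, strain albino) with Rattus norvegicus as the target, with a stated time of 120 min, at a dose of 10 mg/kg by the oral route; a lower number here means less inhibition, a higher number more inhibition at the dose given (going by the name of the read-out).
Compound 2 `COc1ccc(C2N=C(SCc3cccc(Cl)c3)NC(C)=C2C(=O)Nc2ccc(F)cc2)cc1OC` gives 10.8% in this assay.
Compound 3 `CC1=C(C(=O)Nc2ccc(Br)cc2)C(c2ccc(Cl)cc2Cl)N=C(SCc2ccccc2)N1` gives 10.3% in this assay.

Compound 1 and compound 2 share a core and differ only by chloro in place of hydrogen on an aromatic carbon. The step that this change made is a number 2 percentage points higher from compound 1 to compound 2 (within the scatter). Compound 3 is built on a different core; the difference between the two cores is not broken down here. Its value and that of compound 2 lie within the scatter of each other, as do its value and that of compound 1, so no order among the three can be read from these numbers.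

Compound 4 `CC1=C(C(=O)Nc2ccc(Br)cc2)C(c2ccc(Cl)cc2Cl)N=C(SCc2ccccc2Cl)N1` is not yet measured. It stands to compound 3 as compound 2 stands to compound 1, by chloro in place of hydrogen on an aromatic carbon. This is the same kind of change as the earlier one, not the same: in compound 2 the chloro sits meta to a large group, in compound 4 ortho to a large group. Because the earlier step was a number 2 percentage points higher from compound 1 to compound 2 (within the scatter), a step of about a number 1.7 percentage points higher from compound 3 to compound 4 (within the scatter) is expected from compound 3 to compound 4. Compound 4 is estimated at 12%, within 2% to 25%.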

Compound 4, a percentage reported as inhibition, in the whole organism at one dose (the size of the read-out at that dose, not a potency): 16%
For compound 4 the middle estimate is 4 percentage points below the measured one; the range from low to high includes it.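

In this assay, chloro in place of hydrogen on an aromatic carbon, which turns the benzyl of compound 3 into the 2-chlorobenzyl of compound 4, gives a number 5.7 percentage points higher from compound 3 to compound 4 (within the scatter). Set beside the earlier step, this one shows no difference between the two cores that stands out from the usual spread of such measurements: the same change on two cores in this assay, a number 2 percentage points higher (within the scatter) from compound 1 to compound 2 and a number 5.7 percentage points higher (within the scatter) from compound 3 to compound 4, 3.7 percentage points apart, within the scatter of two such steps. The change can therefore be carried from one core to the other without any sign of a different outcome, but neither step on its own shows that the chloro has an effect, and two cores, with the chloro at a different place on the ring in compound 2 and compound 4, are too few to establish a rule for the series.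

The compounds shown leave open whether chloro at one and the same place on the ring would give matching steps on both cores. They also leave open whether a larger group on that ring, such as a methoxy group, a nitrile or a carboxylic acid, would move the inhibition beyond the scatter.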